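The compounds below may be only part of what the source reports. "The series", "measured", "known", "first", "only" and "open" are said of these compounds alone.

Series notes. Compound 1 `CC(=O)c1ccc(NC(=O)C2CC(O)CN2S(=O)(=O)c2ccc(C)cc2)cc1` carries a hydroxy on the five-membered ring and a methyl on an aromatic carbon of the sulfonyl aryl group; in a functional assay, read by spectrophotometry, with a stated time of 20 min (on this read-out higher numbers stand for weaker inhibition and lower numbers for stronger inhibition), compound 1 gives 25000000 nM. Compound 2 `CC(=O)c1ccc(NC(=O)C2CCCN2S(=O)(=O)c2ccc([N+](=O)[O-])cc2)cc1` has no hydroxy on the five-membered ring and a nitro-substituted sulfonyl aryl group; in this assay compound 2 gives 19000000 nM. Compound 3 `CC(=O)c1ccc(NC(=O)C2CC(O)CN2S(=O)(=O)c2ccccc2)cc1` keeps the hydroxy and has an unsubstituted phenylsulfonyl group; in this assay compound 3 gives 3800000 nM, the lowest of the three numbers, with compound 2 nearest to it and compound 1 furthest from it. Among the compounds with values here, the only single-point step measured so far is a 6.6-fold lower number from compound 1 to compound 3 (0.82 log units; beyond the scatter).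

Compound 4 `CC(=O)c1ccc(NC(=O)C2CCCN2S(=O)(=O)c2ccccc2)cc1` differs from compound 3 by hydrogen in place of hydroxy on a saturated ring carbon. Within the data shown here, no measured step covers this change: the step from compound 1 to compound 3 concerns the aromatic methyl, and compound 2 differs from compound 4 in the nitro group as well, so its value shows only that a hydroxy-free analogue gives a higher number than compound 3 without isolating the hydroxy. With nothing pointing in either direction, the expected step of a 1.1-fold higher number from compound 3 to compound 4 (0.02 log units; within the scatter) is small, with a wide band on either side. Compound 4 is estimated at 4000000 nM, between 1000000 nM and 16000000 nM, in this assay.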

Compound 4, half-maximal inhibitory concentration: 69000000 nM
Beside the measured number, compound 4's estimate is 17-fold (1.24 log units) below it; measured number outside the range, above it.
By their numbers in this assay, from the lowest: compound 3; then compounds 2 and 1 (each within the scatter of the next); then compound 4.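

The hydroxy on the saturated ring carbon, two ring bonds from the ring nitrogen, now has a single-change reading: in this assay, hydrogen in its place gives an 18-fold higher number from compound 3 to compound 4 (1.26 log units; beyond the scatter), so this position is not indifferent to the change, and the lower number belongs to the hydroxy compound. The sulfonyl aryl group also gains a second reading, a 3.6-fold higher number from compound 2 to compound 4 (0.56 log units; beyond the scatter), and here hydrogen in place of nitro raises the number on the hydroxy-free background, whereas hydrogen in place of methyl lowers it on the hydroxy background in a 6.6-fold lower number from compound 1 to compound 3 (0.82 log units; beyond the scatter), so hydrogen on that aromatic carbon has no single direction across these pairs. No measurement available here accounts for either the hydroxy step or the opposite directions of the aryl steps.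

The compounds shown leave open whether the hydroxy step keeps its size with a methyl or nitro on the sulfonyl aryl group, and whether the methyl and nitro steps would still run in opposite directions on one shared background. They also leave open what a methoxy, a fluorine or an amine would give on the same saturated ring carbon, and so whether the result is particular to hydroxy.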